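Methoxy for bromo on the isopropoxy-bearing ring

The source may hold more compounds than are shown below. What is called first, only, known or untested is meant among the compounds shown, and "the series" means these compounds.

Within the data shown here, compound 2 `Cc1cc(CCC(=O)O)ccc1-c1noc(-c2ccc(OC(C)C)c(Br)c2)n1` gives the lowest number of the two measured so far in a functional assay on CHO cells for agonist activity at sphingosine 1-phosphate receptor 5 (Homo sapiens), read by GTPgammaS binding (a higher number here means that more compound is needed for the effect, a lower number that less compound is needed), with 43 nM. Among the measured compounds shown here, its only neighbour is compound 1 `Cc1cc(CCC(=O)O)ccc1-c1noc(-c2ccc(OC(C)C)c(F)c2)n1`, which in this assay gives 530 nM; the single measured step, a 12-fold lower number from compound 1 to compound 2 (1.09 log units; beyond the scatter), is bromo in place of fluoro on an aromatic carbon. Compound 3 `COc1cc(-c2nc(-c3ccc(CCC(=O)O)cc3C)no2)ccc1OC(C)C` has not yet been measured. It differs from compound 2 by methoxy in place of bromo on an aromatic carbon. For the measured compounds named here, the one measured step bears on this change only in that it alters the same position: it shows that the group at that carbon moves the number well beyond the scatter, but methoxy has no measured precedent here, so neither the direction nor the size of the step can be read from the data. The expectation for compound 3 is therefore a number between those of the two measured compounds, most likely somewhat higher than that of compound 2, written as a 2.6-fold higher number from compound 2 to compound 3 (0.41 log units; beyond the scatter). Compound 3 is estimated at 110 nM, with a range from 25 nM to 450 nM.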

Compound 3, half-maximal effective concentration: 270 nM
Compound 3: the middle estimate sits 2.5-fold (0.39 log units) below what was measured, within the range that was stated.
By their numbers in this assay, from the lowest: compound 2; then compounds 3 and 1 (each within the scatter of the next).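

In this assay, methoxy on this aromatic carbon, ortho to an isopropoxy group, does not retain the low number seen with bromo: the change gives a 6.3-fold higher number from compound 2 to compound 3 (0.80 log units; beyond the scatter) and so removes much of the gain that bromo showed over fluoro. Set against fluoro, methoxy gives a 2.0-fold lower number from compound 1 to compound 3 (0.29 log units; within the scatter), so these two groups cannot be told apart at this carbon, and among the three groups bromo alone stands clear of the others. Nothing measured here accounts for the separation of bromo from fluoro and methoxy.

From the compounds shown here alone, it remains open whether the low number belongs to bromo alone or extends to other groups at this carbon, such as chloro, methyl or trifluoromethyl, and whether a longer ethoxy chain would stay level with methoxy. Going by these compounds, all three compounds also carry the same isopropoxy group, so it is unknown whether the gap between bromo and methoxy would persist with a different group there, such as cyclopropylmethoxy.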